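Methoxy to 4-Fluorophenyl: Expected Cytotoxicity of Compound 3

The source may hold more compounds than are shown below. What is called first, only, known or untested is meant among the compounds shown, and "the series" means these compounds.

Compound 1 `C=C[C@@](C)(/C=C/c1ccc(OC)cc1)CCC=C(C)C` is the reference point of this short series. In an ADME assay on HEK293 cells (Homo sapiens) for cytotoxicity, with a stated time of 72 h (a lower number here means that less compound is needed, a higher number that more compound is needed for the effect), compound 1 gives only a limit, > 36600 nM, and not a number. Compound 2 `C=C[C@@](C)(/C=C/c1ccc(Nc2ccc(OC)c(F)c2)cc1)CCC=C(C)C` is the other measured member. In this assay compound 2 likewise gives only a limit, > 36600 nM. Both results sit at the same limit, (the limit of > 36600 nM in this assay, at which 2 of the 2 values shown sit), so compound 1 stands at that limit together with compound 2, and neither shows a measurable effect within the tested range. Going by the values given here, no step between two measured compounds that differ in one place can be drawn from these two structures.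

Compound 3 `C=C[C@@](C)(/C=C/c1ccc(-c2ccc(F)cc2)cc1)CCC=C(C)C` has not yet been tested in this assay. It differs from compound 1 in a single place: 4-fluorophenyl in place of methoxy on an aromatic carbon. The step that the limit leaves unreadable from compound 1 to compound 3 is expected to be none beyond the usual scatter, resting on the limit of > 36600 nM in this assay, at which 2 of the 2 values shown sit, at which compound 1 sits. Compound 3 is therefore estimated at 40000 nM, with a range from 15000 nM to 100000 nM, and most likely the assay will again report only a limit.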

Compound 3, half-maximal effective concentration: > 36600 nM
Compound 3: only a limit was reported (the forecaster's own chance of this, stated with the estimate: 70%); the middle value does not contradict the limit.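

In this assay, going by these compounds alone, compound 3 gives only a limit, > 36600 nM, and compound 1 also gives only a limit, so no step from compound 1 to compound 3 can be read: the limit of > 36600 nM in this assay, at which 3 of the 3 values shown sit. The compounds shown leave open at what concentration, if any, each of them would reach the half-maximal effect.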